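The compounds below may be only part of what the source reports. "The series", "measured", "known", "first", "only" and "open" are said of these compounds alone.

Of the compounds shown here, three sharing one core have been measured in an assay on isolated protein for inhibition of aldehyde dehydrogenase 1A1 (Homo sapiens), read by spectrophotometry, tested at 10 uM; on this read-out higher numbers stand for more inhibition at the one concentration tested (going by the name of the read-out) and lower numbers for less inhibition. Compound 1 `Cc1cccc(Cn2c(CN3CCN(C(=O)c4ccncc4)CC3)nc3ccccc32)c1` gives 20.6%. Compound 2 `O=C(C1CC1)N1CCN(Cc2nc3ccccc3n2Cc2ccccc2)CC1` gives 23.9%. Compound 3 `Cc1cccc(Cn2c(CN3CCN(C(=O)C4CCCCC4)CC3)nc3ccccc32)c1` gives 31.9%. On these numbers compound 2 stands second highest of the three, yet its gap to compound 1 and its gap to compound 3 both lie within the usual scatter, so the three cannot be ranked against each other. Going by the values given here, the only pair that differs in a single place is compound 1 and compound 3, where the change on the carbonyl carbon gives a number 11.3 percentage points higher from compound 1 to compound 3 (beyond the scatter).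

Compound 4 `O=C(C1CC1)N1CCN(Cc2nc3ccccc3n2CC2CCCC2)CC1` has not yet been measured. It differs from compound 2 by cyclopentyl in place of phenyl on a saturated chain carbon bound to an aromatic nitrogen. Among the compounds with values here, no measured pair isolates this position: compound 1 and compound 3 carry a different group on the saturated chain carbon bound to the aromatic nitrogen than compound 2 does, but each also differs from compound 2 at the carbonyl, so their values show nothing about this change alone. The step of a number 11.3 percentage points higher from compound 1 to compound 3 (beyond the scatter) concerns another position and does not bear on it. With nothing to lean on, the step from compound 2 is expected to stay within the scatter, at a number 1.1 percentage points higher from compound 2 to compound 4 (within the scatter). Compound 4 is thus estimated at 25%, in a range from 8% to 42%.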

Compound 4, a percentage reported as inhibition, at one concentration (the size of the read-out at that concentration, not a potency): 44.5%
The estimate for compound 4 lay 19.5 percentage points below the measured number, outside the stated range (above it).
By their numbers in this assay, from the lowest: compounds 1, 2 and 3 (each within the scatter of the next, the first and the last beyond it); then compound 4.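

In this assay, the group on the saturated chain carbon bound to an aromatic nitrogen proves to matter, since cyclopentyl in place of phenyl gives a number 20.6 percentage points higher from compound 2 to compound 4 (beyond the scatter). Going by these compounds alone, until now, the only readable step concerned the group on the carbonyl carbon, so this is the first sign that the other end of the shared core also moves the number, with the cyclopropyl carbonyl held fixed. The change takes out an aromatic ring of 6 heavy atoms and puts in a non-aromatic ring of 5, with neither group carrying hydrogen-bond donors or acceptors, and nothing on hand explains why the number climbs with this swap.

The compounds shown leave open whether the gain from cyclopentyl would hold with the cyclohexyl or pyridin-4-yl carbonyl in place of the cyclopropyl carbonyl, as this one step was read on a single background. They also leave open whether a cyclobutyl or cyclohexyl ring, an open butyl chain or a ring bearing an amine on the same saturated chain carbon would follow cyclopentyl or fall back towards phenyl.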